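Chain extension in the series, compound 3 to compound 4

The compounds below may be only part of what the source reports. "The series", "measured", "known", "first", "only" and "open" are said of these compounds alone.

In a functional assay on CCRF-CEM cells (Homo sapiens) for cytotoxicity (on this read-out higher numbers stand for lower toxicity in this test and lower numbers for higher toxicity in this test), compound 1 (`CCCCCCCCCC(=O)Nc1nc(N)nc2c1ncn2[C@H]1CO[C@@H](CO)O1`) gives 65000 nM, compound 2 (`CCCCCCCCCCCC(=O)Nc1nc(N)nc2c1ncn2[C@H]1CO[C@@H](CO)O1`) gives 13000 nM and compound 3 (`CCCCCCCCCCCCCC(=O)Nc1nc(N)nc2c1ncn2[C@H]1CO[C@@H](CO)O1`) gives 4600 nM, the lowest of the three numbers. Compound 4 (`CCCCCCCCCCCCCCCC(=O)Nc1nc(N)nc2c1ncn2[C@H]1CO[C@@H](CO)O1`) is reached by ethyl in place of hydrogen on a saturated chain carbon, ten or more bonds along the chain from a carbonyl carbon. Two measured ethyl additions bear on this: a 5.0-fold lower number from compound 1 to compound 2 (0.70 log units; beyond the scatter) and a 2.8-fold lower number from compound 2 to compound 3 (0.45 log units; beyond the scatter). Both are modest, beyond the scatter and point to lower numbers. Three compounds give only a short trend, so a further modest fall in this assay is expected, with the estimated step of a 2.1-fold lower number from compound 3 to compound 4 (0.32 log units; beyond the scatter). For compound 4 the estimated value is 2200 nM, with an expected range of 1000 nM to 5000 nM.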

Compound 4, half-maximal cytotoxic concentration: > 100000 nM
Compound 4 ended at the assay's limit; the forecaster's own chance of this, stated with the estimate: 5%; at least 45-fold (1.65 log units) between middle value and limit.
By their numbers in this assay, from the lowest: compound 3; then compound 2; then compound 1. At a limit, above all of these: compound 4.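

In this assay compound 4 stands at > 100000 nM, which is a limit of the assay and not a number. Here chain extension turns the trend round, with an at least 21-fold higher number from compound 3 to compound 4 (1.33 log units; beyond the scatter) and an at least 7.6-fold higher number from compound 2 to compound 4 (0.88 log units; beyond the scatter), while an at least 1.5-fold higher number from compound 1 to compound 4 (0.18 log units; that floor lies within the scatter) sets no order. The fall in numbers with chain length holds only from compound 1 to compound 3, and compound 4 goes against it: the same change on two cores in this assay, a 5.0-fold lower number (0.70 log units; beyond the scatter) from compound 1 to compound 2 and an at least 21-fold higher number (1.33 log units; beyond the scatter) from compound 3 to compound 4, at least 100-fold (2.03 log units) apart, beyond the scatter of two such steps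

On these data alone, the true size of the rise stays open, since only a limit is available. Also open, as far as these compounds go, is how a chain of intermediate length, a longer chain or a chain carrying a carboxylic acid would read out.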